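The source may report more compounds than this note shows. Statements on the series, on what has been measured and on what is new or still open speak of the compounds shown alone.

Of the compounds shown here, three have been measured in a functional assay on COLO 205 cells (Homo sapiens) for inhibition, read by sulforhodamine B assay, with a stated time of 48 h, tested at 100 uM; a lower number here means less inhibition of growth, a higher number more inhibition of growth at the concentration tested. Compound 1, with the structure `O=c1c(C2N=C(c3ccccc3)SS2)coc2cc(Cl)ccc12`, gives 57%. Compound 2, with the structure `O=c1c(C(=S)Nc2ccccc2)coc2ccccc12`, gives 71%, and compound 3, with the structure `O=c1c(C(=S)Nc2ccccc2)coc2ccc(F)cc12`, gives 26%. The difference between the cores of compound 1 and compound 2 is not broken down here.

Compound 2 and compound 3 differ in one place only: fluoro in place of hydrogen on an aromatic carbon. This change brought a number 45 percentage points lower from compound 2 to compound 3 (beyond the scatter).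

Compound 4, with the structure `O=c1c(C2N=C(c3ccccc3)SS2)coc2cc(Cl)c(F)cc12`, has not yet been measured in this assay. It differs from compound 1 in one place: fluoro in place of hydrogen on an aromatic carbon. Among the measured compounds shown here, this is the same kind of change as the one from compound 2 to compound 3, not the same change: in compound 4 the entering fluoro sits ortho to a chloro group, and the place in compound 3 has no such neighbour. The change occurs twice among these compounds, and only one of those two occurrences has been measured.

Because compound 3 gives 26% after fluoro entered the core of compound 2, a downward step from compound 1 is expected, estimated as a number 25 percentage points lower from compound 1 to compound 4 (beyond the scatter). The surroundings of the place and the core itself differ from the measured pair, and a single measured example is a thin basis. Compound 4 is expected to give about 32% in this assay. Four of five measurements of compound 4 would be expected to fall between 10% and 58%.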

Compound 4, percent growth inhibition at one concentration: 45%
For compound 4 the middle estimate is 13 percentage points below the measured one, within the range that was stated.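

In this assay, fluoro in place of hydrogen on an aromatic carbon gave a number 12 percentage points lower from compound 1 to compound 4 (beyond the scatter), the same direction as on the other core, but the size of the step did not carry over: the same change on two cores in this assay, a number 45 percentage points lower (beyond the scatter) from compound 2 to compound 3 and a number 12 percentage points lower (beyond the scatter) from compound 1 to compound 4, 33 percentage points apart, beyond the scatter of two such steps

So in the two measured pairs, this swap goes with less inhibition of growth at the concentration tested, but a step measured on one core is a poor guide to the size of the step on another. These two pairs do not show why the steps differ, since both the core and the surroundings of the fluoro change between them: in compound 4 the fluoro sits ortho to a chloro group, and in compound 3 it has no such neighbour.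

The compounds shown leave open whether fluoro would give a step closer in size to that of the other pair if it entered the core of compound 1 at a place not ortho to a chloro group. They also leave open how that same place on the ring would respond to a different group, such as a methoxy group, an amine or a carboxylic acid, in place of the fluoro.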